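The compounds below may be only part of what the source reports. "The series", "measured", "known", "first", "only" and "open" are said of these compounds alone.

Working notes on the series. Compound 1 is `O=S(=O)(Nc1ccc2oc(-c3ccccc3)nc2c1)c1cccc(F)c1`. In an assay on isolated protein for inhibition of malate dehydrogenase, mitochondrial (Sus scrofa), with stated times of 45 min and 30 min (a lower number here means a stronger inhibitor, a higher number a weaker inhibitor), compound 1 gives > 63000 nM, which is a limit of the assay and not a number. Compound 2 is `O=S(=O)(Nc1ccc(-c2nc3ccccc3o2)cc1)c1ccc(F)c(C(F)(F)F)c1`; in this assay compound 2 gives > 63000 nM, again a limit and not a number. Compound 3 is `O=S(=O)(Nc1ccc2oc(-c3ccccc3)nc2c1)c1ccc(Cl)c(C(F)(F)F)c1`; in this assay compound 3 gives > 63000 nM, once more a limit rather than a number. Where compound 1 stands among these three therefore cannot be told: the only thing shown is the limit of > 63000 nM in this assay, at which 3 of the 3 values shown sit, so no compound can be ranked against another and no step between measured compounds exists.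

Compound 4 is `O=S(=O)(Nc1ccc2oc(-c3ccccc3)nc2c1)c1cccc(O)c1`. The change from compound 1 to compound 4 is hydroxy in place of fluoro on an aromatic carbon. For the measured compounds named here, no measured pair in this set shows what such a swap does in this assay, and with every value sitting at a limit there is no direction to lean on. The expectation is a step from compound 1 to compound 4 of a step that the limit leaves unreadable from compound 1 to compound 4, which is none beyond the usual scatter, and most likely another limit rather than a number. For compound 4 in this assay the estimate is 80000 nM, within 20000 nM to 300000 nM.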

Compound 4, half-maximal inhibitory concentration: > 63000 nM
Compound 4 was reported as a limit (the forecaster's own chance of this, stated with the estimate: 85%); the middle value lies beyond the limit too.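

No step can be read from compound 1 to compound 4, because each gives a limit of the assay and not a number: the limit of > 63000 nM in this assay, at which 4 of the 4 values shown sit. The compounds shown leave open what hydroxy in place of fluoro on an aromatic carbon does in this assay, and whether these four compounds differ from one another there at all.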